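Exchanging one group on compound 2

A few compounds are considered here, and "the series" means these few. Any claim that something is new, unique, unknown or untested is made for them only; others in the source may bear on it.

- compound 1 `CCCCCCC(=O)N(CCCC/C=C\CCCCCCC(=O)OCCOCCOCCO)C(C)C` gives 2900 nM
- compound 2 `CCCCCNC(=O)NCCCC/C=C\CCCCCNS(=O)(=O)c1ccccc1` gives 3400 nM
- compound 3 `CCCCCCC(=O)N(CCCC/C=C\CCCCCCc1nnn[nH]1)C(C)C` gives 1000 nM

In a functional assay on Coronary artery (Bos taurus) (a higher number here means that more compound is needed for the effect, a lower number that less compound is needed), compound 2 at 3400 nM lies within the scatter of compound 1 and has a clearly higher number than compound 3. Among the compounds with values here, compound 4 `CCCCCNC(=O)NCCCC/C=C\CCCCCCC1=NOS(=O)N1` differs from compound 2 by a group of 7 heavy atoms (2 carbon, 2 nitrogen, 2 oxygen, 1 sulfur; one five-membered non-aromatic ring with 4 hetero atoms) in place of a group of 10 heavy atoms (6 carbon, 1 nitrogen, 2 oxygen, 1 sulfur; one six-membered aromatic ring of carbon only), on a saturated chain carbon, five bonds along the chain from a double-bonded chain carbon and has no measurement yet. Within the data shown here, one measured step bears on this: a 2.9-fold lower number from compound 1 to compound 3 (0.46 log units; beyond the scatter) when one group on a saturated chain carbon is exchanged. Its groups and core differ from those here, so it is only a loose guide. A modest step to a lower number in this assay is therefore expected. The estimate is a 2.1-fold lower number from compound 2 to compound 4 (0.33 log units; beyond the scatter) and remains uncertain. For compound 4 the expected value is 1600 nM (500 nM to 5000 nM).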

Compound 4, half-maximal effective concentration: 340 nM
Compound 4: middle estimate off by 4.7-fold (0.67 log units), on the high side; the whole stated range lies above it.
By their numbers in this assay, from the lowest: compound 4; then compound 3; then compounds 1 and 2 (each within the scatter of the next).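

In this assay, the exchange at this saturated chain carbon, five bonds along the chain from a double-bonded chain carbon, gives a 10-fold lower number from compound 2 to compound 4 (1.00 log units; beyond the scatter). So on the core of compound 2, the end group at this place has a large influence on the number, which compounds 1 and 3 could show only on a different core. Nothing available explains why this ring lowers the number.

Going by these compounds, it remains open whether the phenylsulfonylamino group's departure or the new ring matters more. A carboxylic acid at this place could help separate the two.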